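A few compounds are considered here, and "the series" means these few. Any claim that something is new, unique, unknown or untested is made for them only; others in the source may bear on it.

Of the compounds shown here, three that share one core have been tested in an in vitro assay on LLC-PK1 cells for displacement of a labelled ligand from growth hormone secretagogue receptor type 1 (Homo sapiens); a lower number here means a stronger inhibitor, a higher number a weaker inhibitor. Compound 1 `COc1ccc(Cn2c(CCc3ccccc3)nnc2[C@H](NC(=O)c2ccncc2)c2c[nH]c3ccccc23)c(OC)c1` gives 58 nM. Compound 2 `COc1ccc(Cn2c(CCc3ccccc3)nnc2[C@H](NC(=O)c2ccncc2)c2c[nH]c3ccccc23)cc1` carries hydrogen in place of methoxy on an aromatic carbon and gives 220 nM, a loss described by the step of a 3.8-fold higher number from compound 1 to compound 2 (0.58 log units; beyond the scatter). Compound 3 `COc1ccc(Cn2c(CCc3ccccc3)nnc2[C@H](NC(=O)c2ccccc2)c2c[nH]c3ccccc23)c(OC)c1` gives 11.8 nM, the lowest of the three numbers; its steps to both other compounds lie beyond the scatter, so within this small set it is the strongest binder. The gain on going from a pyridin-4-yl ring to a phenyl ring on the carbonyl carbon is the step of a 4.9-fold lower number from compound 1 to compound 3 (0.69 log units; beyond the scatter).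

Compound 4 `COc1ccc(Cn2c(CCc3ccccc3)nnc2[C@H](NC(=O)c2cnccn2)c2c[nH]c3ccccc23)c(OC)c1` has not yet been measured. It differs from compound 3 in one place: pyrazin-2-yl in place of phenyl on a carbonyl carbon. Within the data shown here, the only measured step that bears on this is the one from compound 1 to compound 3, in which the phenyl ring that enters here replaced a nitrogen-containing six-membered ring and the number fell. Returning to a six-membered ring with ring nitrogens is therefore expected to move the number back up by a modest amount, roughly the size of that earlier step, with the expected change being a 3.8-fold higher number from compound 3 to compound 4 (0.58 log units; beyond the scatter). Compound 4 is estimated to give about 45 nM, with a likely range from 15 nM to 150 nM.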

Compound 4, half-maximal inhibitory concentration: 5 nM
The estimate for compound 4 lay 9.0-fold (0.95 log units) above the measured number; the measured number lies below the stated range.
By their numbers in this assay, from the lowest: compound 4; then compound 3; then compound 1; then compound 2.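

Read in this assay, the change from phenyl to pyrazin-2-yl on the carbonyl carbon gives a 2.4-fold lower number from compound 3 to compound 4 (0.37 log units; beyond the scatter) and so reverses the direction the earlier compounds suggested: taken alone, the step from compound 1 to compound 3 could have meant that nitrogen in this ring raises the number, but compound 4 shows that a ring with two nitrogens can beat the all-carbon ring. The two nitrogen-containing rings also differ sharply from each other, with a 12-fold lower number from compound 1 to compound 4 (1.06 log units; beyond the scatter) on exchanging pyridin-4-yl for pyrazin-2-yl, so at this position the identity of the ring matters, not just whether it contains nitrogen. No measurement is available that explains this difference between the rings.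

The compounds shown cover only three six-membered aromatic rings at this position, so it remains open how a pyridin-2-yl, a pyrimidin-2-yl, a five-membered thiazol-2-yl or a saturated piperidin-4-yl ring would compare. On these data alone, it is also open whether the loss seen on replacing methoxy with hydrogen in compound 2 would carry over to a compound bearing the pyrazin-2-yl ring.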